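The source may hold more compounds than are shown below. What is called first, only, known or untested is meant among the compounds shown, and "the series" means these compounds.

Compound 2 `Cc1ccc(CN2CCN(CC(=O)Nc3ccc(-c4nc(-c5ccccc5)c(-c5ccccc5)n4C)cc3)CC2)cc1` carries the shared core of compound 1 `CN1CCN(CC(=O)Nc2ccc(-c3nc(-c4ccccc4)c(-c4ccccc4)n3C)cc2)CC1` with a 4-methylphenyl in place of hydrogen on a saturated chain carbon bound to an amine nitrogen in a ring. In a functional assay on HT-29 cells (Homo sapiens) for cytotoxicity, read by MTT assay, with a stated time of 24 h, tested at 16 ug/mL (a lower number here means a weaker effect, a higher number a stronger effect of the compound at the concentration tested), compound 1 gives 33.7%, and compound 2 gives 30.6%; the step of a number 3.1 percentage points lower from compound 1 to compound 2 (within the scatter) leaves the two values within the scatter of each other, so compound 2 stands beside compound 1 rather than apart from it. Compound 3 `Cn1c(-c2ccc(NC(=O)CN3CCN(Cc4ccc(Cl)cc4)CC3)cc2)nc(-c2ccccc2)c1-c1ccccc1` differs from compound 2 by chloro in place of methyl on an aromatic carbon. Among the compounds with values here, no measured step touches this aromatic carbon: the only step in hand, a number 3.1 percentage points lower from compound 1 to compound 2 (within the scatter), concerns the saturated chain carbon and was itself within the scatter. On that basis the step from compound 2 to compound 3 in this assay is expected to be a number 1.4 percentage points higher from compound 2 to compound 3 (within the scatter), no larger than the scatter and in no settled direction. Compound 3 is therefore estimated to give 32% in this assay, with a range from 18% to 46%.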

Compound 3, a percentage reported as activity, at one concentration (the size of the read-out at that concentration, not a potency): 52.9%
The estimate for compound 3 lay 20.9 percentage points below the measured number, and the stated range ends below it.
By their numbers in this assay, from the lowest: compounds 2 and 1 (each within the scatter of the next); then compound 3.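

In this assay, within the data shown here, this aromatic carbon, para to a large group, turns out to be a place where a single-atom exchange counts: chloro in place of methyl gives a number 22.3 percentage points higher from compound 2 to compound 3 (beyond the scatter) and so yields the first step to pass beyond the scatter. The same holds against the unsubstituted end of the comparison, since 4-chlorophenyl in place of hydrogen on the saturated chain carbon gives a number 19.2 percentage points higher from compound 1 to compound 3 (beyond the scatter) while 4-methylphenyl at that carbon had left the number within the scatter, so among these three compounds the outcome at the chain carbon depends on what the phenyl ring carries and not merely on the ring being there. Nothing at hand accounts for the difference between methyl and chloro at this carbon.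

On these data alone, whether the rise belongs to chloro alone or extends to fluoro, bromo, trifluoromethyl or methoxy on the same carbon remains open, as does the effect of chloro on the other carbons of that ring. These numbers also describe a single concentration, so they show the size of the read-out there and leave the potency of compound 3 undefined.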